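The source may report more compounds than this note shows. Statements on the series, on what has been measured and on what is new or still open speak of the compounds shown alone.

Measured compounds:
compound 1 `O=C1NC2CSC(CCCCC(=O)N3CCN(C(=O)COC4=CC(=O)c5ccccc5C4=O)CC3)C2N1` — 1200 nM
compound 3 `CC(C)(C)OC(=O)NCC(CCCCNC(=O)COC1=CC(=O)c2c(O)cccc2C1=O)CNC(=O)CCCCC1SCC2NC(=O)NC21` — 7900 nM
compound 2 `O=C(O)CCCCCNC(=O)COC1=CC(=O)c2c(O)cccc2C1=O` — "not determined" (no result reported)

In a functional assay on T47D cells (Homo sapiens) for antiproliferative activity (on this read-out higher numbers stand for weaker inhibition and lower numbers for stronger inhibition), compound 1 gives 1200 nM, while compound 3 gives 7900 nM. Compound 2 stands without a number; in this assay compound 2 gives "not determined" (no result reported), so its place among these values is unknown. Compound 4 `CC(C)(C)OC(=O)NCCCCCCNC(=O)COC1=CC(=O)c2c(O)cccc2C1=O` differs from compound 2 by a single change: ((tert-butoxycarbonyl)amino)methyl in place of carboxy on a saturated chain carbon, five bonds along the chain from an amide-type nitrogen. For the measured compounds named here, no step between measured compounds is available to size this change. With compound 3, which also carries a tert-butoxycarbonyl group, at 7900 nM, and with compound 2 itself unmeasured, the direction of this step in this assay cannot be inferred from the data; an outcome in the weaker part of the range seen so far seems plausible. Compound 4 is expected to give about 5000 nM in this assay, within 1500 nM to 20000 nM.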

Compound 4, half-maximal inhibitory concentration: 300 nM
The estimate for compound 4 lay 17-fold (1.22 log units) above the measured number; measured number below the stated range.
By their numbers in this assay, from the lowest: compound 4; then compound 1; then compound 3.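

For the compounds shown here, compound 2 has no number in this assay, so no step to compound 4 can be read. The compounds shown leave open what replacing carboxy with ((tert-butoxycarbonyl)amino)methyl does, and no evidence bears on this result.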